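Chloro for methoxy on the aryl ring of compound 2

A few compounds are considered here, and "the series" means these few. Any claim that something is new, unique, unknown or untested is made for them only; others in the source may bear on it.

Compound 1: `Fc1ccc(-c2n[nH]cc2N2CCCNCC2)cc1` gives 1810 nM.
Compound 2: `COc1ccccc1-c1n[nH]cc1N1CCNCC1` gives > 10000 nM.

Both were tested in an assay on isolated protein for binding affinity to 5-hydroxytryptamine receptor 3A (Homo sapiens); a lower number here means a stronger inhibitor, a higher number a weaker inhibitor. For compound 2 the result is only a limit of this assay, (the limit of > 10000 nM in this assay, at which 1 of the 2 values shown sits), so no number stands for compound 2. Compound 3, `Clc1ccccc1-c1n[nH]cc1N1CCNCC1`, carries chloro in place of methoxy on an aromatic carbon. Among the compounds with values here, with compound 2 at a limit, no measured step guides the change; the replacement of methoxy by chloro is expected to alter this assay by no more than the scatter, or to improve it slightly. Compound 3 is therefore estimated at 8000 nM, between 2000 nM and 30000 nM. That estimate means an expected step of an at least 1.2-fold lower number from compound 2 to compound 3 (0.09 log units; that floor lies within the scatter).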

Compound 3, inhibition constant: > 10000 nM
Compound 3 was reported as a limit; the forecaster's own chance of this, stated with the estimate: 45%; middle value at least 1.2-fold (0.09 log units) from the limit.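

In this assay compound 2 and compound 3 both sit at a limit, and the step between them cannot be read: the limit of > 10000 nM in this assay, at which 2 of the 3 values shown sit. The compounds shown leave open how far chloro and methoxy differ in this series.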